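This account rests on a few compounds, and the source may have more. Where it says the series, first, only, none or still open, it means among the compounds named here.

Measured compounds:
- Compound 1, `Cc1nc(C(NC(=O)C(=O)Nc2ccc(F)cc2F)C2CCCCN2)sc1CO`, which in an ADME assay on MT2 cells (Homo sapiens) for cytotoxicity, read by XTT assay, with a stated time of 4 days (on this read-out higher numbers stand for lower toxicity in this test and lower numbers for higher toxicity in this test), gives > 110000 nM, a limit of the test rather than a number.
- Compound 2, `Cc1nc(C(NC(=O)C(=O)Nc2ccc(F)cc2F)C2CCCCN2)sc1CCO`, which in this assay gives > 105000 nM, again a limit of the test rather than a number.

Compound 2 therefore stands at a limit in this assay: the test ran out of concentration before any toxicity was seen, as the limit of > 105000 nM in this assay, at which 1 of the 2 values shown sits, records. Among the compounds with values here, the same holds for compound 1, as the limit of > 110000 nM in this assay, at which 1 of the 2 values shown sits, records, so the only measured step, a step that the two limits leave unreadable from compound 1 to compound 2, cannot be read in size or direction.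

Compound 3, `CC(=O)c1ccc(NC(=O)C(=O)NC(c2nc(C)c(CCO)s2)C2CCCCN2)cc1`, differs from compound 2 by 4-acetylphenyl in place of 2,4-difluorophenyl on an amide-type nitrogen. No measured step touches this part of the shared core, and the one step that exists is unreadable, so no direction and no size can be taken from the numbers shown. The expectation for compound 3 is simply a value at or near the same limit, with the step of an at least 1.0-fold lower number from compound 2 to compound 3 (0.02 log units; that floor lies within the scatter) expected to stay within the scatter. Compound 3 is therefore estimated at 100000 nM, between 40000 nM and 150000 nM.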

Compound 3, half-maximal cytotoxic concentration: > 48300 nM
Compound 3 gave a limit, no number; the forecaster's own chance of this, stated with the estimate: 70%; the middle value lies beyond the limit too.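

In this assay compound 3 gives > 48300 nM, a limit of the test and not a number. Compound 2 also stands at a limit, so the step between compound 2 and compound 3 cannot be read in size or direction. The compounds shown leave open whether 4-acetylphenyl in place of 2,4-difluorophenyl changes the half-maximal cytotoxic concentration at all.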